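The compounds below may be only part of what the source reports. "The series", "measured", "known", "first", "only" and "open" are said of these compounds alone.

Measured in a physicochemical assay for solubility, read by HPLC, using the shake flask method, in phosphate buffer, with a stated time of 2 h, at pH 6.5; a lower number here means a less soluble compound, a higher number a more soluble compound:
- compound 1 `Nc1ncc(-c2ccc(C(=O)N3CC[C@@H](O)C3)cc2)nc1-c1ccc(C(F)(F)F)cc1`: 90000 nM
- compound 2 `Nc1ncc(-c2ccc(C(=O)O)cc2)nc1-c1ccc(C(F)(F)F)cc1`: 95000 nM
- compound 3 `COC(=O)c1ccc(-c2cnc(N)c(-c3ccc(C(F)(F)F)cc3)n2)cc1`: < 5000 nM (a limit, not a number)

Compound 3 has no exact number in this assay and stands only at a limit: the limit of < 5000 nM in this assay, at which 1 of the 3 values shown sits.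

Compound 4 `Nc1ncc(-c2ccc(C(=O)N3CCC(N)C3)cc2)nc1-c1ccc(C(F)(F)F)cc1` has 3-aminopyrrolidin-1-yl in place of methoxy on a carbonyl carbon.

For the measured compounds named here, three measured steps bear on this change. With methoxy in place of 3-hydroxypyrrolidin-1-yl, the result is an at least 18-fold lower number from compound 1 to compound 3 (1.25 log units; beyond the scatter). With methyl in place of hydrogen on the oxygen, it is an at least 19-fold lower number from compound 2 to compound 3 (1.27 log units; beyond the scatter). Both are large, and both lead to the methoxy group that compound 4 gives up. By contrast, a 1.1-fold higher number from compound 1 to compound 2 (0.02 log units; within the scatter) lies within the scatter. The group closest to the entering one is 3-hydroxypyrrolidin-1-yl, found in compound 1 at 90000 nM.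

A large rise of similar size is therefore expected, namely an at least 18-fold higher number from compound 3 to compound 4 (1.25 log units; beyond the scatter).

Compound 4 is estimated at 90000 nM, with an expected range of 35000 nM to 200000 nM.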

Compound 4, solubility: 102000 nM
Estimate against measurement, compound 4: 1.1-fold (0.05 log units) below; low and high end bracket the measured number.
By their numbers in this assay, from the lowest: compounds 1, 2 and 4 (each within the scatter of the next). At a limit, below all of these: compound 3.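

In this assay, the picture on this carbonyl carbon is now sharper, as a third group separates from methoxy by a large margin (an at least 20-fold higher number from compound 3 to compound 4 (1.30 log units; beyond the scatter)). 3-Aminopyrrolidin-1-yl cannot be told apart from either hydroxy (a 1.1-fold higher number from compound 2 to compound 4 (0.03 log units; within the scatter)) or 3-hydroxypyrrolidin-1-yl (a 1.1-fold higher number from compound 1 to compound 4 (0.05 log units; within the scatter)), so among the four compounds shown, only compound 3 stands apart, and exchanging the hydroxy on the pyrrolidine ring for an amine makes no difference beyond the scatter. On these data alone, the value of compound 3 is a limit, not a number, so the full size of its gap stays unknown: the limit of < 5000 nM in this assay, at which 1 of the 4 values shown sits.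

As far as these compounds go, whether an unsubstituted pyrrolidin-1-yl amide, with no amine or hydroxy on the ring, would sit with compound 3 or with the other three remains open. So does the place of an ethyl ester or of an amide carrying a longer open chain.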